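This account rests on a few compounds, and the source may have more. Where it says the series, first, only, none or still open, it means among the compounds named here.

Compound 1 `O=C(CN1CCC(c2cccc[n+]2[O-])CC1)Nc1cccc(Cl)c1` is the reference point. In a functional assay on HEK293 cells for agonist activity at D(4) dopamine receptor (Homo sapiens), read by FLIPR (a lower number here means that less compound is needed, a higher number that more compound is needed for the effect), compound 1 gives 62 nM, the lowest of the three numbers seen so far, although compound 3 `Cc1cc(Br)ccc1NC(=O)CN1CCC(c2cccc[n+]2[O-])CC1` sits within the scatter of it with 66 nM. Compound 2 `O=C(CN1CCC(c2cccc[n+]2[O-])CC1)Nc1cc(Cl)cc(Cl)c1` gives 160 nM, the furthest of the three from compound 1.

Compound 4 `O=C(CN1CCC(c2cccc[n+]2[O-])CC1)Nc1cccc(OC(F)(F)F)c1` differs from compound 1 in one place: trifluoromethoxy in place of chloro on an aromatic carbon. The change sits on an aromatic carbon of a six-membered aromatic ring of carbon only, meta to a large group.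

Going by the values given here, three measured steps touch the same part of the molecule. The step of a 2.6-fold higher number from compound 1 to compound 2 (0.41 log units; beyond the scatter) adds a second chloro and is modest. The step of a 1.1-fold higher number from compound 1 to compound 3 (0.03 log units; within the scatter) exchanges the whole group on the amide-type nitrogen and stays within the scatter. The step of a 2.4-fold lower number from compound 2 to compound 3 (0.38 log units; beyond the scatter) is modest in the other direction. Among the compounds with values here, none of them tests a trifluoromethoxy, so the measured steps show only that changes here have moved the number by small amounts, not which way this one will go.

The step from compound 1 to compound 4 is therefore expected to be small, at most modest, a 1.5-fold higher number from compound 1 to compound 4 (0.16 log units; within the scatter). Compound 4 is estimated at 90 nM, with a range from 40 nM to 250 nM.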

Compound 4, half-maximal effective concentration: 135 nM
Compound 4: middle estimate off by 1.5-fold (0.18 log units), on the low side; measured number inside the range.
By their numbers in this assay, from the lowest: compounds 1 and 3 (each within the scatter of the next); then compounds 4 and 2 (each within the scatter of the next).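

In this assay, going by these compounds alone, the single chloro of compound 1 has now been replaced directly by a larger group, and the change gives a 2.2-fold higher number from compound 1 to compound 4 (0.34 log units; beyond the scatter), which is modest but beyond the scatter. This place on the aromatic ring therefore accepts trifluoromethoxy, with five heavy atoms in place of one, while agonist activity remains and the number rises only modestly; the other step that keeps the chloro of compound 1 and changes this ring, a 2.6-fold higher number from compound 1 to compound 2 (0.41 log units; beyond the scatter), also raises the number, whereas compound 3, with its different ring substitution, stays within the scatter of compound 1. No measurement shown here explains why the number rises with trifluoromethoxy.

From the compounds shown here alone, what a methoxy, a fluoro or an amine would do at this same place remains open, as does whether a plain hydrogen there would give a lower or a higher number than chloro. Going by these compounds, it is also open whether the step from chloro to trifluoromethoxy would have a similar size on another carbon of the ring or with a different group on the rest of the shared core.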